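Removing a Boc Group From a Pyrrolidine-Bearing Kinase Scaffold

The source may hold more compounds than are shown below. What is called first, only, known or untested is meant among the compounds shown, and "the series" means these compounds.

Four compounds share a core in which a pyrrolidine ring is attached to a fused bicyclic heteroaromatic system carrying an anilino group. Compound 1 `CN1CCN(c2ccc(Nc3ncc4nc(Nc5ccccc5)n([C@H]5CCN(C(=O)OC(C)(C)C)C5)c4n3)cc2)CC1` carries a tert-butoxycarbonyl group on the pyrrolidine nitrogen and a plain phenyl ring on the aniline. Compound 2 `CN1CCN(c2ccc(Nc3ncc4nc(Nc5ccccc5)n([C@H]5CCNC5)c4n3)cc2)CC1` is the same except that the tert-butoxycarbonyl group is gone, a change summarised as hydrogen in place of tert-butoxycarbonyl on an amine nitrogen in a ring. Compound 3 `CN1CCN(c2ccc(Nc3ncc4nc(Nc5ccc(F)cc5)n([C@@H]5CCN(C(=O)OC(C)(C)C)C5)c4n3)cc2)CC1` bears a fluorine on the aniline ring together with the tert-butoxycarbonyl group; the difference between the core of compound 3 and that of compound 1 is not broken down here. Compound 4 `CN1CCN(c2ccc(Nc3ncc4nc(Nc5ccc(F)cc5)n([C@@H]5CCNC5)c4n3)cc2)CC1` stands to compound 3 as compound 2 stands to compound 1, the change being (hydrogen in place of tert-butoxycarbonyl on an amine nitrogen in a ring), a change of the same kind at the same kind of place.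

In a functional assay on HCC827 cells (Homo sapiens) for antiproliferative activity, read by MTT assay, with a stated time of 72 h (on this read-out lower numbers stand for stronger inhibition and higher numbers for weaker inhibition), compound 1 gives 110 nM. Compound 2 gives 530 nM, and the step of a 4.8-fold higher number from compound 1 to compound 2 (0.68 log units; beyond the scatter) shows that removing the tert-butoxycarbonyl group weakened antiproliferative activity in this assay. Compound 3 gives 27 nM, the lowest number of the three.

Because the step of a 4.8-fold higher number from compound 1 to compound 2 (0.68 log units; beyond the scatter) was modest but clearly beyond the scatter, the same change on the fluorinated core is expected to move activity by a similar amount, so compound 4 is estimated at 130 nM, with a range of 50 nM to 400 nM thought likely, an expected step of a 4.8-fold higher number from compound 3 to compound 4 (0.68 log units; beyond the scatter).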

Compound 4, half-maximal inhibitory concentration: 300 nM
Beside the measured number, compound 4's estimate is 2.3-fold (0.36 log units) below it, within the range that was stated.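

Removing the tert-butoxycarbonyl group from the pyrrolidine nitrogen gives an 11-fold higher number from compound 3 to compound 4 (1.05 log units; beyond the scatter) in this assay, which is the same direction as a 4.8-fold higher number from compound 1 to compound 2 (0.68 log units; beyond the scatter). One step is labelled large and the other modest, but that label should not be over-read, since the two sizes cannot be told apart on these data and the change carries over from one core to the other with a similar result: the same change on two cores in this assay, a 4.8-fold higher number (0.68 log units; beyond the scatter) from compound 1 to compound 2 and an 11-fold higher number (1.05 log units; beyond the scatter) from compound 3 to compound 4, 2.3-fold (0.36 log units) apart, within the scatter of two such steps. Among these compounds, this shows only that the change weakens activity in these two matched pairs; it does not show why the tert-butoxycarbonyl group is favoured, nor that the same step would appear on a core outside this set.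

The compounds shown leave open how other groups on the pyrrolidine nitrogen, such as a methyl group, an acetyl group or a longer carbon chain, would compare with tert-butoxycarbonyl and hydrogen in this assay. They also leave open how much the fluorine alone contributes, since the core of compound 1 and the core of compound 3 differ in more than that one atom, and a separate comparison that changes only the fluorine would be needed to settle it.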